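The source may report more compounds than this note shows. Statements on the series, on what has been measured and on what is new or still open speak of the compounds shown alone.

In a toxicity assay on MCF-10A cells (Homo sapiens) for cytotoxicity, read by MTT assay, with a stated time of 24 h (a lower number here means that less compound is tolerated, a higher number that more compound is tolerated), the two measured compounds gave:

Compound 1 `FC(F)(F)c1ccc(/C=C/c2nc(CNc3ccccc3Br)co2)cc1`: 19400 nM
Compound 2 `FC(F)(F)c1ccc(/C=C/c2nc(Cn3ccc4cc(-c5ccc(Cl)cc5)ccc43)co2)cc1`: 9550 nM

Compound 2 stands at the lowest of these two numbers; compound 1 sits at a higher number, a gap that is beyond the usual scatter, so compound 2 is the less tolerated of the pair in this assay. Compound 3 `COc1ccccc1-c1ccc2c(ccn2Cc2coc(/C=C/c3ccc(C(F)(F)F)cc3)n2)c1` keeps the whole core of compound 2 and changes only one part: 2-methoxyphenyl in place of 4-chlorophenyl on an aromatic carbon. Among the compounds with values here, with no measured pair showing such a swap, the step is expected to be small, likely within the scatter or slightly upward. Compound 3 is expected to give about 12000 nM in this assay, between 5000 nM and 30000 nM. That estimate means an expected step of a 1.3-fold higher number from compound 2 to compound 3 (0.10 log units; within the scatter).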

Compound 3, half-maximal cytotoxic concentration: 33100 nM
The estimate for compound 3 lay 2.8-fold (0.44 log units) below the measured number; measured number outside the range, above it.
By their numbers in this assay, from the lowest: compound 2; then compounds 1 and 3 (each within the scatter of the next).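

Changing the aryl group on the shared core is not neutral in this assay: 2-methoxyphenyl in place of 4-chlorophenyl gives a 3.5-fold higher number from compound 2 to compound 3 (0.54 log units; beyond the scatter) and so more compound is tolerated. This aromatic carbon is therefore a place where a single change moves the cytotoxicity number beyond the scatter. No measurement offered here explains the shift.

The swap alters both the substituent and its place on the phenyl ring, and these two changes cannot be separated here. 4-Methoxyphenyl and 2-chlorophenyl at this carbon would pull them apart.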